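Amide chain variation on the dihydropyridine series

This account rests on a few compounds, and the source may have more. Where it says the series, first, only, none or still open, it means among the compounds named here.

Measured compounds:
compound 1, `CCO/C(O)=C1\C(COCCNC(C)=O)=NC(C)=C(C(=O)OC)C1c1ccccc1Cl` — 15.9 nM
compound 2, `CCO/C(O)=C1\C(COCCN(C)C(=O)NC)=NC(C)=C(C(=O)OC)C1c1ccccc1Cl` — 20 nM

In a functional assay (aorta) with Rattus norvegicus as the target (a higher number here means a weaker inhibitor, a lower number a stronger inhibitor), compound 1 holds the lowest of the two numbers; the nearest is compound 2, and the step of a 1.3-fold higher number from compound 1 to compound 2 (0.10 log units; within the scatter) lies within the scatter. Both compounds share the same core and differ only at the end of the chain that carries the amide.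

Compound 3, `CCO/C(O)=C1\C(COCCNCC(N)=O)=NC(C)=C(C(=O)OC)C1c1ccccc1Cl`, is not yet measured. Relative to compound 1 it shows (carbamoylmethyl in place of acetyl on an amine nitrogen). For the measured compounds named here, the only measured step that bears on this change is the one from compound 1 to compound 2, which alters the same chain end and gave a 1.3-fold higher number from compound 1 to compound 2 (0.10 log units; within the scatter). On that basis no shift beyond the scatter is expected in this assay. For compound 3 the estimated value is 18 nM, with a range from 7 nM to 45 nM. This estimate corresponds to an expected step of a 1.1-fold higher number from compound 1 to compound 3 (0.05 log units; within the scatter).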

Compound 3, half-maximal inhibitory concentration: 3.98 nM
Compound 3: middle estimate off by 4.5-fold (0.66 log units), on the high side; measured number below the stated range.
By their numbers in this assay, from the lowest: compound 3; then compounds 1 and 2 (each within the scatter of the next).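

In this assay the end of this chain proves able to move the number beyond the scatter, which the earlier pair did not show: carbamoylmethyl in place of acetyl on the amine nitrogen gives (a 4.0-fold lower number from compound 1 to compound 3 (0.60 log units; beyond the scatter)), and the comparison with the methyl(methylcarbamoyl)amino chain end gives (a 5.0-fold lower number from compound 2 to compound 3 (0.70 log units; beyond the scatter)). The change swaps acetyl, with 0 hydrogen-bond donors, for carbamoylmethyl, with 1 hydrogen-bond donor, and it also adds a carbon between the amine nitrogen and the carbonyl, so these compounds cannot separate the two differences. No supporting data bear on why the number falls.

As far as these compounds go, whether the terminal carbamoyl group is needed remains open, as a carboxylic acid or a simple ethyl group on the same nitrogen would test it. From the compounds shown here alone, the effect of a longer chain between that nitrogen and the carbamoyl group also remains open.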